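Swapping the 3,5-difluorophenyl group of compound 2

The source may report more compounds than this note shows. Statements on the series, on what has been measured and on what is new or still open speak of the compounds shown alone.

In an ADME assay on MT4 cells (Homo sapiens) for cytotoxicity, read by MTT assay, with a stated time of 4 days (a lower number here means that less compound is tolerated, a higher number that more compound is tolerated), compound 1 `Cc1ccc(OCCn2cc(C)c(=O)n(Cc3ccccc3)c2=O)cc1` gives > 356000 nM, which is a limit of the assay and not a number. Within the data shown here, compound 2 `O=c1ccn(C/C=C/c2ccccc2)c(=O)n1Cc1cc(F)cc(F)c1` gives 31000 nM, the only exact number so far, so it has no exact partner for comparison. Compound 3 `Cc1cc(Br)cc(Cn2c(=O)ccn(C/C=C/c3ccccc3)c2=O)c1` differs from compound 2 in one group: 3-bromo-5-methylphenyl in place of 3,5-difluorophenyl on a saturated chain carbon bound to an aromatic nitrogen. Here, 3-bromo-5-methylphenyl takes the place of 3,5-difluorophenyl on a saturated chain carbon bound to an aromatic nitrogen. Among the measured compounds shown here, no measured pair shows what such a swap does, so the expectation is anchored on compound 2 at 31000 nM and remains uncertain. In this assay, a modest step towards less compound being tolerated is expected, a 1.6-fold lower number from compound 2 to compound 3 (0.19 log units; within the scatter). Compound 3 is estimated at 20000 nM, with an expected range of 6000 nM to 70000 nM.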

Compound 3, half-maximal cytotoxic concentration: 100000 nM
Compound 3: middle estimate off by 5.0-fold (0.70 log units), on the low side, outside the stated range (above it).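

Among these compounds, this is the first measured step at this position, and it shows that changing the aromatic group on the saturated chain carbon bound to an aromatic nitrogen has a readable effect. In this assay, putting 3-bromo-5-methylphenyl in place of 3,5-difluorophenyl gives a 3.2-fold higher number from compound 2 to compound 3 (0.51 log units; beyond the scatter), so more compound is tolerated after the swap, by a step beyond the usual scatter. Nothing shown here accounts for this rise.

Bromine and methyl both enter in this one swap while both fluorines leave, so the share of each in the step remains open. Also open, from the compounds shown here alone, is how the number would move with a more different group on this ring, such as an amine or a carboxylic acid.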